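From 1H-pyrrol-2-yl to 3-methylthiophen-2-yl in compound 1

A few compounds are considered here, and "the series" means these few. Any claim that something is new, unique, unknown or untested is made for them only; others in the source may bear on it.

Compound 1 `C=C(Br)C(=O)Nc1ccc2c(c1)/C(=C/c1ccc[nH]1)C(=O)N2`: 110 nM
Compound 2 `C#CC(=O)Nc1ccc2c(c1)/C(=C/c1ccc[nH]1)C(=O)N2`: 340 nM

In a functional assay on Jurkat cells (Homo sapiens) for antiproliferative activity, read by MTT assay, with a stated time of 72 h (on this read-out higher numbers stand for weaker inhibition and lower numbers for stronger inhibition), compound 1 gives 110 nM, the lower of the two numbers, and compound 2 gives 340 nM. Compound 3 `C=C(Br)C(=O)Nc1ccc2c(c1)/C(=C/c1sccc1C)C(=O)N2` keeps the 1-bromoethenyl group on the carbonyl carbon of compound 1 and differs elsewhere: 3-methylthiophen-2-yl stands in place of 1H-pyrrol-2-yl on a double-bonded chain carbon bound to a double-bonded ring carbon (3-methylthiophen-2-yl in place of 1H-pyrrol-2-yl on a double-bonded chain carbon bound to a double-bonded ring carbon).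

Among the compounds with values here, the only measured step, a 3.1-fold higher number from compound 1 to compound 2 (0.49 log units; beyond the scatter), is modest but beyond the scatter. It comes from ethynyl replacing 1-bromoethenyl on a carbonyl carbon, so it bears on this exchange only as a rough guide to size. Within the data shown here, no measured pair varies the group at the changed place, and the direction is therefore poorly supported. A small move towards a higher number in this assay is expected, no larger than the measured step. The estimated step is a 1.8-fold higher number from compound 1 to compound 3 (0.26 log units; within the scatter). For compound 3 the expected value is 200 nM, with an estimated range from 60 nM to 600 nM.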

Compound 3, half-maximal inhibitory concentration: 530 nM
Beside the measured number, compound 3's estimate is 2.7-fold (0.42 log units) below it, and the stated range covers the measured number.
By their numbers in this assay, from the lowest: compound 1; then compounds 2 and 3 (each within the scatter of the next).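

In this assay, within the data shown here, the exchange of 1H-pyrrol-2-yl for 3-methylthiophen-2-yl gives a 4.8-fold higher number from compound 1 to compound 3 (0.68 log units; beyond the scatter), the first measured change on the double-bonded chain carbon bound to a double-bonded ring carbon; the earlier step concerned only the group on the carbonyl carbon. Among these compounds, the group at this place therefore also moves the number, and compound 1 remains the lowest of the three, but the single step bundles several changes: nitrogen gives way to sulfur in the ring, a methyl enters, and the hydrogen-bond donor counted on the leaving group is lost. No measurement at hand explains the size or direction of this step.

Open, on these data alone, is how a thiophen-2-yl group without the methyl, or a 1-methylpyrrol-2-yl group, would read at this place, as either would help separate the ring exchange, the methyl and the donor from one another. Also open, as far as these compounds go, is whether the exchange gives a step of similar size and direction when ethynyl, rather than 1-bromoethenyl, sits on the carbonyl carbon.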